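Chloro for methoxy on the shared core of compound 2

The source may hold more compounds than are shown below. What is called first, only, known or untested is meant among the compounds shown, and "the series" means these compounds.

Measured compounds:
compound 1 `COc1cc(/C=C/C(=O)c2cccc(-n3cc(-c4ccc(Cl)cc4)[nH]c3=O)c2)cc(OC)c1OC` — 2000 nM
compound 2 `COc1ccc(-c2cn(-c3cccc(C(=O)/C=C/c4ccc(O)c(OC)c4)c3)c(=O)[nH]2)cc1` — 3840 nM
compound 3 `COc1ccc(-c2cn(-c3cccc(C(=O)/C=C/c4cc(OC)c(OC)c(OC)c4)c3)c(=O)[nH]2)cc1` — 1280 nM

Three compounds were measured in a functional assay on HT-29 cells (Homo sapiens) for inhibition; a lower number here means a stronger inhibitor of growth, a higher number a weaker inhibitor of growth. Compound 3 gives 1280 nM, and compound 1, which carries the change (chloro in place of methoxy on an aromatic carbon), gives 2000 nM; the resulting step is a 1.6-fold higher number from compound 3 to compound 1 (0.19 log units; within the scatter). Compound 2 gives 3840 nM, and its core differs from that of compound 3 by 4-hydroxy-3-methoxyphenyl in place of 3,4,5-trimethoxyphenyl on a double-bonded chain carbon bound to a double-bonded chain carbon, which corresponds to the step of a 3.0-fold lower number from compound 2 to compound 3 (0.48 log units; beyond the scatter).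

Compound 4 `COc1cc(/C=C/C(=O)c2cccc(-n3cc(-c4ccc(Cl)cc4)[nH]c3=O)c2)ccc1O` has not been measured in this assay. It differs from compound 2 by chloro in place of methoxy on an aromatic carbon. This is the same change already seen between compound 3 and compound 1, occurring twice among these compounds, and the place is described in identical words in both cases, so it is regarded as the same change on a different core.

Among the compounds with values here, since the only measured instance of this change, the step from compound 3 to compound 1, stays within the scatter, the expected step from compound 2 to compound 4 is estimated as a 1.4-fold higher number from compound 2 to compound 4 (0.16 log units; within the scatter), resting on a 1.6-fold higher number from compound 3 to compound 1 (0.19 log units; within the scatter) as the single precedent. Because compound 2 gives 3840 nM, compound 4 is expected to show about 5500 nM in this assay, with a plausible range from 2500 nM to 12000 nM.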

Compound 4, concentration for 50% growth inhibition: 2970 nM
Compound 4: the middle estimate sits 1.9-fold (0.27 log units) above what was measured; measured number inside the range.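

In this assay, chloro in place of methoxy on the core of compound 2 gives a step of a 1.3-fold lower number from compound 2 to compound 4 (0.11 log units; within the scatter). Neither this step nor the earlier one lies beyond the scatter, and they do not differ from each other, so within these two cores the change carries over with no effect that can be read: the same change on two cores in this assay, a 1.6-fold higher number (0.19 log units; within the scatter) from compound 3 to compound 1 and a 1.3-fold lower number (0.11 log units; within the scatter) from compound 2 to compound 4, 2.0-fold (0.31 log units) apart, within the scatter of two such steps. This does not give the change a direction, as the two steps are each too small to separate from the scatter, and two cores cannot show how the change would behave on other cores in the series.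

The compounds shown carry only methoxy or chloro on this aromatic carbon, para to a large group, so it remains open how fluoro, trifluoromethyl, an amine or a carboxylic acid would compare there. The group on the double-bonded chain carbon is likewise only 4-hydroxy-3-methoxyphenyl or 3,4,5-trimethoxyphenyl, which leaves open whether the chloro for methoxy change would stay as small with an unsubstituted phenyl or a pyridine in that place.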